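A few compounds are considered here, and "the series" means these few. Any claim that something is new, unique, unknown or untested is made for them only; others in the source may bear on it.

Compound 1 `O=C1NCCN(c2cccc(Cl)n2)N1` gives 4800 nM in a functional assay on cells for inhibition of Polyunsaturated fatty acid 5-lipoxygenase (Homo sapiens); a lower number here means a stronger inhibitor, a higher number a weaker inhibitor. Among the three measured compounds it stands second highest: compound 3 `O=C1NCCN(c2cccc(-c3ccsc3)c2)N1` gives 5300 nM, within the usual scatter of compound 1, while compound 2 `CC1CN(c2cccc(Cl)n2)NC(=O)N1` gives 1600 nM, the one measured single change being a 3.0-fold lower number from compound 1 to compound 2 (0.48 log units; beyond the scatter), a modest step. Compound 4 `O=C1NCCN(c2cccc(-c3cccs3)n2)N1` differs from compound 1 by thiophen-2-yl in place of chloro on an aromatic carbon. Within the data shown here, no measured step concerns this exchange; the step from compound 1 to compound 2 alters a different part of the structure, and compound 3, which carries a related ring elsewhere, gives a value within the scatter of compound 1. In this assay a step no larger than the scatter is therefore expected. Compound 4 is estimated at 5000 nM, between 2000 nM and 12000 nM. That expectation amounts to a 1.0-fold higher number from compound 1 to compound 4 (0.02 log units; within the scatter).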

Compound 4, half-maximal inhibitory concentration: 37000 nM
For compound 4 the middle estimate is 7.4-fold (0.87 log units) below the measured one; the measured number lies above the stated range.
By their numbers in this assay, from the lowest: compound 2; then compounds 1 and 3 (each within the scatter of the next); then compound 4.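

Replacing chloro with thiophen-2-yl on this aromatic carbon, next to the ring nitrogen, makes the compound a weaker inhibitor in this assay (a 7.7-fold higher number from compound 1 to compound 4 (0.89 log units; beyond the scatter)). Among these compounds, the earlier compounds held no change at this carbon, so this is the first sign that the group placed here affects the result. Nothing available explains why the number rises.

From the compounds shown here alone, whether an amine or a methoxy group here would match chloro remains open. So does whether the methyl on the saturated ring carbon that helped compound 2 would also lower the number of compound 4.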